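A few compounds are considered here, and "the series" means these few. Any claim that something is new, unique, unknown or untested is made for them only; others in the source may bear on it.

Of the two compounds measured, compound 2 `COC(=O)CNCCCOc1ccc2cc(NC(=O)c3ccc(O)c(CC=C(C)C)c3)c(=O)oc2c1C` carries the higher number. For the measured compounds named here, in a functional assay on MCF7 cells (Homo sapiens) for antiproliferative activity (on this read-out higher numbers stand for weaker inhibition and lower numbers for stronger inhibition), compound 2 gives 2820 nM, while compound 1 `CC(C)=CCc1cc(C(=O)Nc2cc3ccc(OCCC4CCCCN4)c(C)c3oc2=O)ccc1O` gives 710 nM; the only measured step, a 4.0-fold higher number from compound 1 to compound 2 (0.60 log units; beyond the scatter), runs in the direction of weaker inhibition and lies beyond the usual scatter. Compound 3 `CC(C)=CCc1cc(C(=O)Nc2cc3ccc(OCCCN[C@H](C)c4ccccc4)c(C)c3oc2=O)ccc1O` has not yet been measured. It differs from compound 2 in one place: 1-phenylethyl in place of (methoxycarbonyl)methyl on an amine nitrogen. Going by the values given here, no measured pair shows exactly this exchange, so the guide is indirect. The step from compound 1 to compound 2 put the (methoxycarbonyl)methyl group onto the amine and weakened inhibition modestly; compound 3 takes that group away again and puts a 1-phenylethyl group in its stead, so a return towards the number of compound 1 seems the more likely outcome, though the new group may move the number either way. For compound 3 a modest gain is expected, a step of a 2.8-fold lower number from compound 2 to compound 3 (0.45 log units; beyond the scatter) from compound 2, giving an estimated 1000 nM in this assay, with a plausible range from 300 nM to 3000 nM.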

Compound 3, half-maximal inhibitory concentration: 1450 nM
Estimate against measurement, compound 3: 1.5-fold (0.16 log units) below; low and high end bracket the measured number.
By their numbers in this assay, from the lowest: compound 1; then compounds 3 and 2 (each within the scatter of the next).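

In this assay, the exchange of (methoxycarbonyl)methyl for 1-phenylethyl on the amine nitrogen gives a 1.9-fold lower number from compound 2 to compound 3 (0.29 log units; within the scatter), so two groups that differ in size, in the presence of an aromatic ring and in their oxygen atoms cannot be told apart at this position. The new compound also gives a second comparison with the piperidin-2-yl compound: the change to ((1-phenylethyl)amino)methyl gives a 2.0-fold higher number from compound 1 to compound 3 (0.31 log units; beyond the scatter), a modest step that points the same way as the earlier step from compound 1 to compound 2. Among these three compounds, then, both open-chain amines carry higher numbers than the piperidin-2-yl compound, while the choice of group on the open-chain nitrogen has shown no effect beyond the scatter. No measurement is at hand that would account for these numbers.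

The compounds shown leave open whether a smaller substituent, such as a single methyl group, or an unsubstituted amine would bring the number closer to that of compound 1. They also leave open whether the opposite mirror-image form of 1-phenylethyl, or a benzyl group with no stereocentre, would read any differently.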